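Triazole ring, aryl group in place of an anilide side chain

The source may hold more compounds than are shown below. What is called first, only, known or untested is meant among the compounds shown, and "the series" means these compounds.

Three measured compounds share one core with a trifluoromethyl group and differ at the ester or acid and at the heteroaryl side chain. In a functional assay on HeLa cells (Homo sapiens) for inhibition, read by MTT assay, with a stated time of 24 h (a higher number here means a weaker inhibitor, a lower number a stronger inhibitor), compound 1, `O=C(O)C1=Cc2ccccc2OC1(OCc1cc(-c2ccc(F)cc2)no1)C(F)(F)F`, gives only a limit of the assay, > 150000 nM. For the measured compounds named here, compound 3, `CCOC(=O)C1=Cc2ccccc2OC1(OCc1cc(-c2cccc(C(F)(F)F)c2)no1)C(F)(F)F`, is the one compound with a number in this assay, 21400 nM. Compound 2, `CCOC(=O)C1=Cc2ccccc2OC1(OCc1cn(CC(=O)Nc2ccccc2Br)nn1)C(F)(F)F`, likewise reaches only a limit in this assay, > 150000 nM. Going by the values given here, compound 2 thus stands at the limit of > 150000 nM in this assay, at which 2 of the 3 values shown sit, so its true position is unknown and no measured step within the set can be used as a guide.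

Compound 4, `CCOC(=O)C1=Cc2ccccc2OC1(OCc1cn(-c2cccc(OC)c2)nn1)C(F)(F)F`, differs from compound 2 by 3-methoxyphenyl in place of ((2-bromophenyl)carbamoyl)methyl on an aromatic nitrogen. The change brings an aromatic ring directly onto the five-membered ring, which is how the side chain of compound 3 is built, and compound 3 gives 21400 nM. On that basis a step toward a lower number, beyond the usual scatter, is expected, but the size is open since compound 2 is a limit. The estimate for compound 4 in this assay is 60000 nM, within 15000 nM to 200000 nM, which would mean an expected step of an at least 2.5-fold lower number from compound 2 to compound 4 (0.39 log units; beyond the scatter). The chance that compound 4 also returns only a limit remains substantial.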

Compound 4, half-maximal inhibitory concentration: > 150000 nM
Compound 4: no number, only a limit; the forecaster's own chance of this, stated with the estimate: 45%; middle value at least 2.5-fold (0.39 log units) away from the limit.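

In this assay, for the compounds shown here, compound 4 returns only a limit, as compound 2 does, so no step between compound 2 and compound 4 can be read: the limit of > 150000 nM in this assay, at which 3 of the 4 values shown sit.

The compounds shown leave open where the true values of compound 2 and compound 4 lie, and which of the two side chains gives the lower number.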